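A few compounds are considered here, and "the series" means these few. Any claim that something is new, unique, unknown or untested is made for them only; others in the source may bear on it.

Measured in a functional assay on K562 cells (Homo sapiens), read by MTT assay, with a stated time of 72 h; on this read-out higher numbers stand for weaker inhibition and lower numbers for stronger inhibition:
- Compound 1 `COc1ncnc2c1c(-c1cc3ccccc3o1)cn2[C@@H]1O[C@H](CO)[C@@H](O)[C@H]1O`: 20900 nM
- Compound 2 `C#Cc1cn([C@@H]2O[C@H](CO)[C@@H](O)[C@H]2O)c2ncnc(N(C)C)c12`: 110 nM
- Compound 3 `Cc1nc(N)c2c(-c3ccoc3)cn([C@@H]3O[C@H](CO)[C@@H](O)[C@H]3O)c2n1`: > 20000 nM

For compound 3, > 20000 nM is a limit of the assay and not a number.

Compound 4 `Cc1nc(N)c2c(-c3cc4ccccc4o3)cn([C@@H]3O[C@H](CO)[C@@H](O)[C@H]3O)c2n1` differs from compound 3 in one place, with 1-benzofuran-2-yl in place of furan-3-yl on an aromatic carbon. The entering group brings an additional six-membered aromatic ring of carbon only.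

For the measured compounds named here, no two measured compounds differ in just one place, so the effect of this swap has not been seen directly. The nearest guide is compound 1, which carries the same 1-benzofuran-2-yl group on a differently substituted core and gives 20900 nM. Compound 2 lacks this group and gives 110 nM, but it differs from compound 4 in more than one place and offers little guidance here.

Going by compound 1 at 20900 nM, the benzofuran group is not expected to bring strong inhibition. The step expected in this assay is none beyond the usual scatter, a number no higher from compound 3 to compound 4 (the limit leaves the size open). Compound 4 is estimated at 20000 nM, with an expected range from 6000 nM to 40000 nM.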

Compound 4, half-maximal inhibitory concentration: 15700 nM
Compound 4: the middle estimate sits 1.3-fold (0.11 log units) above what was measured; low and high end bracket the measured number.
By their numbers in this assay, from the lowest: compound 2; then compounds 4 and 1 (each within the scatter of the next).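

In this assay, 1-benzofuran-2-yl in place of furan-3-yl on this aromatic carbon gives an at least 1.2-fold lower number from compound 3 to compound 4 (0.10 log units; that floor lies within the scatter), the first direct view of a change at this place. The entering group brings an additional six-membered aromatic ring of carbon only, and with it compound 4 gives 15700 nM, a measured number rather than a limit. From the compounds shown here alone, compound 3 has only a limit, and the full size of the step stays unknown because of it: the limit of > 20000 nM in this assay, at which 1 of the 4 values shown sits.

Going by these compounds, it remains open whether a simple phenyl ring or furan-2-yl on this carbon would behave in the same way, which would help separate the effect of the added ring from that of the changed attachment. An amine or a carboxylic acid at this place also remains untested among the compounds shown.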